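This account rests on a few compounds, and the source may have more. Where it says the series, first, only, none or still open, it means among the compounds named here.

Measured compounds:
Compound 1 `CN(C)C(=O)c1cccc(C#Cc2cc(Cl)ccc2OCC(=O)O)c1` gives 52 nM in an assay on CHO cells for displacement of a labelled ligand from prostaglandin D2 receptor 2 (Homo sapiens), read by scintillation counting; on this read-out higher numbers stand for weaker inhibition and lower numbers for stronger inhibition.
Compound 2 `CCS(=O)(=O)c1ccc(C)c(C#Cc2cc(Cl)ccc2OCC(=O)O)c1` gives 8.6 nM in this assay.
Compound 3 `CCCS(=O)(=O)c1ccc(F)c(C#Cc2cc(Cl)ccc2OC(C)C(=O)O)c1` gives 3 nM in this assay.

Among these three numbers compound 2 holds the second highest: compound 3 sits at a lower number, a gap beyond the scatter, and compound 1 at a higher number, also beyond the scatter. Compound 4 `Cc1ccc(S(=O)(=O)N(C)C)cc1C#Cc1cc(Cl)ccc1OCC(=O)O` is not yet measured. It differs from compound 2 in one place: dimethylamino in place of ethyl on a sulfonyl sulfur. Among the compounds with values here, no pair of measured compounds shows this change, so no measured step guides it directly. In this assay the move from ethylsulfonyl to dimethylsulfamoyl is expected to bring only a small shift, within the scatter or a mild rise, namely a 1.4-fold higher number from compound 2 to compound 4 (0.14 log units; within the scatter). Compound 4 is therefore estimated at 12 nM, in a range from 4 nM to 40 nM.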

Compound 4, inhibition constant: 5 nM
Estimate against measurement, compound 4: 2.4-fold (0.38 log units) above; low and high end bracket the measured number.
By their numbers in this assay, from the lowest: compounds 3, 4 and 2 (each within the scatter of the next, the first and the last beyond it); then compound 1.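

Until compound 4, the sulfonyl sulfur in these compounds had carried only carbon chains. In this assay the change to dimethylamino in place of ethyl on a sulfonyl sulfur gives a 1.7-fold lower number from compound 2 to compound 4 (0.24 log units; within the scatter) and so shows that a nitrogen-linked group can stand at this place with no shift that can be told from the scatter. Nothing measured here bears on the reason for this result. The compounds shown leave open how a bare amino group or a morpholine ring would read on the same sulfur. They also leave open whether dimethylamino would behave alike in a compound with the oxygen-linked propanoic acid chain of compound 3.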